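Plasma unbound fraction across a methylsulfonyl carbamoyl linker change

The source may hold more compounds than are shown below. What is called first, only, known or untested is meant among the compounds shown, and "the series" means these compounds.

Measured in an ADME assay on a cell-free system (plasma, Homo sapiens) for protein binding, read by LC-MS, tested at 5 uM; a higher number here means a larger unbound share of the compound, a lower number a smaller unbound share:
- compound 1 `CS(=O)(=O)NC(=O)CCc1cn(-c2ccc(Cl)cc2)nc1-c1ccc(Cl)cc1` gives 0.00023
- compound 2 `CS(=O)(=O)NC(=O)/C=C/c1cn(-c2ccc(Cl)cc2)nc1-c1ccncc1` gives 0.00015

Compound 2, at 0.00015, lies within the scatter of compound 1, so the two values cannot be separated. Compound 3 `CS(=O)(=O)NC(=O)OCc1cn(-c2ccc(Cl)cc2)nc1-c1ccncc1` has not yet been measured. In compound 3, (((methylsulfonyl)carbamoyl)oxy)methyl takes the place of 2-((methylsulfonyl)carbamoyl)ethenyl on an aromatic carbon ((((methylsulfonyl)carbamoyl)oxy)methyl in place of 2-((methylsulfonyl)carbamoyl)ethenyl on an aromatic carbon).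

Among the compounds with values here, no measured step covers this change, so the expectation rests on two values only: compound 1 at 0.00023 and compound 2 at 0.00015. No shift beyond the scatter is expected in this assay, and no direction can be firmly assigned. The expected step is a 1.3-fold higher number from compound 2 to compound 3 (0.12 log units; within the scatter), which stays within the scatter. For compound 3 the estimated unbound fraction is 0.0002, with an expected range of 0.00008 to 0.0006.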

Compound 3, unbound fraction: 0.0003
Compound 3: middle estimate off by 1.5-fold (0.18 log units), on the low side, and the stated range covers the measured number.
By their numbers in this assay, from the lowest: compounds 2, 1 and 3 (each within the scatter of the next).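

In this assay, (((methylsulfonyl)carbamoyl)oxy)methyl in place of 2-((methylsulfonyl)carbamoyl)ethenyl on the aromatic carbon next to the ring atom that bears a pyridin-4-yl group gives a 2.0-fold higher number from compound 2 to compound 3 (0.30 log units; within the scatter). This exchange of linker therefore gives no separable shift in unbound fraction at this position, even though the atoms joining the (methylsulfonyl)carbamoyl end to the shared core differ between the two compounds. No other data bear on this result.

As far as these compounds go, whether a carboxylic acid or an amine at this position, or a longer chain, would move the unbound fraction beyond the scatter stays open. Also open, from the compounds shown here alone, is whether the same linker exchange would read alike with a 4-chlorophenyl group in place of the pyridin-4-yl group.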